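Swapping an acetoxy group for bromine on a chromone core

A few compounds are considered here, and "the series" means these few. Any claim that something is new, unique, unknown or untested is made for them only; others in the source may bear on it.

Of the compounds shown here, three sharing one core have been measured in a functional assay on A549 cells (Homo sapiens) for cytotoxicity, with a stated time of 48 h; on this read-out higher numbers stand for weaker inhibition and lower numbers for stronger inhibition. Compound 1, `CC(=O)Oc1ccc2oc(/C=C/[S+](C)[O-])cc(=O)c2c1`, gives 4100 nM and stands highest of the three numbers. Compound 2, `C[S+]([O-])/C=C/c1cc(=O)c2cc(F)ccc2o1`, gives 2100 nM, and compound 3, `COc1ccc2oc(/C=C/[S+](C)[O-])cc(=O)c2c1`, gives 1600 nM. The step from compound 1 to compound 2 was a 2.0-fold lower number from compound 1 to compound 2 (0.29 log units; within the scatter), and the step from compound 1 to compound 3 was a 2.6-fold lower number from compound 1 to compound 3 (0.41 log units; beyond the scatter).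

Compound 4, `C[S+]([O-])/C=C/c1cc(=O)c2cc(Br)ccc2o1`, differs from compound 1 as follows: bromo in place of acetoxy on an aromatic carbon. The most relevant comparison is the exchange of the same acetoxy group for fluoro, which gave only a small change, so the expected step of a 1.9-fold lower number from compound 1 to compound 4 (0.27 log units; within the scatter) is likewise small and downward. Compound 4 is therefore estimated at 2200 nM in this assay, within a range of 1000 nM to 4800 nM.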

Compound 4, half-maximal inhibitory concentration: 1100 nM
For compound 4 the middle estimate is 2.0-fold (0.30 log units) above the measured one; the measured number falls inside the stated range.
By their numbers in this assay, from the lowest: compounds 4, 3, 2 and 1 (each within the scatter of the next, the first and the last beyond it).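

In this assay, bromo in place of acetoxy gives a 3.7-fold lower number from compound 1 to compound 4 (0.57 log units; beyond the scatter), a step on an aromatic carbon that clears the usual scatter, as the exchange for fluoro did not. Against the other two groups, bromo gives a 1.5-fold lower number from compound 3 to compound 4 (0.16 log units; within the scatter) and a 1.9-fold lower number from compound 2 to compound 4 (0.28 log units; within the scatter), so bromo, methoxy and fluoro cannot be told apart at this place.

No measurement shown explains these numbers. Going by these compounds, how an amine, a carboxylic acid or a longer chain would behave on this aromatic carbon remains open.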